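A few compounds are considered here, and "the series" means these few. Any claim that something is new, unique, unknown or untested is made for them only; others in the source may bear on it.

In an assay on HEK293 cells for displacement of a labelled ligand from corticotropin-releasing factor receptor 1 (Homo sapiens) (a lower number here means a stronger inhibitor, a higher number a weaker inhibitor), compound 2 `CCCCCN(CCCC)c1cc(C)nc2c(-c3ccc(Cl)cc3Cl)nn(C)c12` gives 0.9 nM, the lowest of the two numbers, and its nearest neighbour is compound 1 `CCCCCN(CCC)c1cc(C)nc2c(-c3ccc(Cl)cc3Cl)nn(C)c12`, which gives 1.2 nM. For the measured compounds named here, the single measured step, a 1.3-fold lower number from compound 1 to compound 2 (0.12 log units; within the scatter), lies within the scatter. Compound 3 `CCCCN(CC1CCCN1C)c1cc(C)nc2c(-c3ccc(Cl)cc3Cl)nn(C)c12` carries 1-methylpyrrolidin-2-yl in place of butyl on a saturated chain carbon bound to a nitrogen on an aromatic ring. That measured step concerns only the length of a plain chain, so nothing among the two measured compounds speaks directly to a ring at this place. The step from compound 2 to compound 3 is therefore expected to be modest, a 3.3-fold higher number from compound 2 to compound 3 (0.52 log units; beyond the scatter), with wide uncertainty. Compound 3 is expected to give 3 nM, within a range from 0.6 nM to 15 nM.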

Compound 3, inhibition constant: 380 nM
Compound 3: middle estimate off by 130-fold (2.10 log units), on the low side, and the stated range ends below it.
By their numbers in this assay, from the lowest: compounds 2 and 1 (each within the scatter of the next); then compound 3.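

The step of a 420-fold higher number from compound 2 to compound 3 (2.63 log units; beyond the scatter) in this assay shows that this position, on a saturated chain carbon bound to a nitrogen on an aromatic ring, is far from indifferent to what it carries. The plain-chain step a 1.3-fold lower number from compound 1 to compound 2 (0.12 log units; within the scatter) gave no sign of such sensitivity. The compounds shown leave open whether the ring, its nitrogen or the methyl on that nitrogen accounts for the change, and whether a cyclopentylmethyl group or an open-chain amine would behave alike. No evidence is available that bears on this large step.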